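From methyl to methoxy on a compound at the limit

A few compounds are considered here, and "the series" means these few. Any claim that something is new, unique, unknown or untested is made for them only; others in the source may bear on it.

Compound 1 `CC(C)(C)n1cc2c(n1)C(=O)CC1(CCN(C(=O)c3cc(-c4ccc(Cl)cc4)nc4ccccc34)CC1)O2`: 2330 nM
Compound 2 `CN1CCN(c2cc(C(=O)N3CCC4(CC3)CC(=O)c3nn(C(C)(C)C)cc3O4)c3ccccc3n2)CC1`: > 10000 nM, a limit
Compound 3 `Cc1cc(C(=O)N2CCC3(CC2)CC(=O)c2nn(C(C)(C)C)cc2O3)c2ccccc2n1`: > 10000 nM, a limit

All three compounds were tested in a functional assay on A549 cells (Homo sapiens) for inhibition, read by MTT assay, with a stated time of 72 h; on this read-out higher numbers stand for weaker inhibition and lower numbers for stronger inhibition. Compound 3 gives > 10000 nM, which is a limit and not a number. Across the set, that means (the limit of > 10000 nM in this assay, at which 2 of the 3 values shown sit).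

Compound 4 `COc1cc(C(=O)N2CCC3(CC2)CC(=O)c2nn(C(C)(C)C)cc2O3)c2ccccc2n1` keeps the core of compound 3 and changes one group: methoxy in place of methyl on an aromatic carbon. In words, this is methoxy in place of methyl on an aromatic carbon, next to the ring nitrogen.

Among the measured compounds shown here, no measured step makes this exact swap. The closest evidence comes from the steps that remove 4-chlorophenyl, which give an at least 4.2-fold higher number from compound 1 to compound 3 (0.63 log units; beyond the scatter) and an at least 4.2-fold higher number from compound 1 to compound 2 (0.63 log units; beyond the scatter). The remaining comparison gives a step that the two limits leave unreadable from compound 2 to compound 3, so it cannot separate methyl from 4-methylpiperazin-1-yl.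

Methoxy, like those two groups, replaces 4-chlorophenyl, and only compound 1 retains that group. On the strength of an at least 4.2-fold higher number from compound 1 to compound 3 (0.63 log units; beyond the scatter), no step beyond the scatter is expected in this assay, and another limit is the likeliest report. The estimated step is a step that the limit leaves unreadable from compound 3 to compound 4. For compound 4 the estimated value is 12000 nM, with an expected range from 5000 nM to 30000 nM.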

Compound 4, half-maximal inhibitory concentration: > 10000 nM
Compound 4: no number, only a limit (the forecaster's own chance of this, stated with the estimate: 75%); the middle value does not contradict the limit.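

In this assay compound 4 gives > 10000 nM, which is a limit and not a number. Methoxy in place of 4-chlorophenyl gives an at least 4.2-fold higher number from compound 1 to compound 4 (0.63 log units; beyond the scatter), so a third replacement at this position, after methyl and 4-methylpiperazin-1-yl, also loses the measurable value that compound 1 has. Adding an oxygen and its hydrogen-bond acceptor to the small group of compound 3 does not bring the result back into the measurable range, and compound 1 remains the only compound shown with a number, the others sitting at one ceiling: the limit of > 10000 nM in this assay, at which 3 of the 4 values shown sit.

The steps among compound 2, compound 3 and compound 4 cannot be read, as both ends of each are limits, so methyl, methoxy and 4-methylpiperazin-1-yl cannot be ranked against one another. On these data alone, it also remains open whether the measurable value of compound 1 needs the chlorine or only the ring that carries it, a question that a plain phenyl at this position would address, while a 4-methoxyphenyl would show whether other groups on that ring serve as well.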